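Amide variation on the tetrahydroquinoline series: ethyl versus cyclobutyl

A few compounds are considered here, and "the series" means these few. Any claim that something is new, unique, unknown or untested is made for them only; others in the source may bear on it.

The series is followed in an assay on CHO cells for displacement of a labelled ligand from melatonin receptor type 1A (Homo sapiens), with a stated time of 120 min; on this read-out higher numbers stand for weaker inhibition and lower numbers for stronger inhibition. For the measured compounds named here, compound 2 `O=C(NCC1CCc2ccccc2N1Cc1ccccc1)C1CCC1` gives 633 nM, the highest of the two numbers measured so far. Going by the values given here, compound 3 `CCNC(=O)NCC1CCc2c(OC)cccc2N1C` gives 5 nM, a difference from compound 2 that lies beyond the scatter; the two structures differ in more than one place, so no single step is drawn between them. Compound 1 `CCC(=O)NCC1CCc2ccccc2N1CC(=O)NC` gives > 10000 nM, which is a limit of this assay and not a number, (the limit of > 10000 nM in this assay, at which 1 of the 3 values shown sits).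

Compound 4 `CCC(=O)NCC1CCc2ccccc2N1Cc1ccccc1` is the next member to be measured. It differs from compound 2 in one place: ethyl in place of cyclobutyl on a carbonyl carbon. The shared core and the substituent on the ring nitrogen stay as in compound 2.

Among the compounds with values here, no measured pair in the set isolates this exchange, so the size of the step is uncertain. Both groups are small hydrocarbons on the carbonyl carbon, and the expectation is a step of modest size, if any, more likely toward a lower number than a higher one. Compound 4 is therefore expected to give about 400 nM in this assay, within a range of 100 nM to 2000 nM, which corresponds to an estimated step of a 1.6-fold lower number from compound 2 to compound 4 (0.20 log units; within the scatter).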

Compound 4, inhibition constant: 37 nM
Estimate against measurement, compound 4: 11-fold (1.03 log units) above; measured number below the stated range.
By their numbers in this assay, from the lowest: compound 3; then compound 4; then compound 2. At a limit, above all of these: compound 1.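

In this assay, the group on the carbonyl carbon proves to be a sensitive place in this series: ethyl in place of cyclobutyl gives a 17-fold lower number from compound 2 to compound 4 (1.23 log units; beyond the scatter), so the exchange of one small hydrocarbon group for another is not a neutral change here. With the propanoylamino group held constant, a second place also counts, as phenyl in place of methylcarbamoyl on a saturated chain carbon bound to a nitrogen on an aromatic ring in a ring gives an at least 270-fold lower number from compound 1 to compound 4 (2.43 log units; beyond the scatter). That step starts from compound 1, whose value is a limit of the assay and not a number: the limit of > 10000 nM in this assay, at which 1 of the 4 values shown sits.

Ethyl and cyclobutyl alone cannot separate the loss of the ring from the change in carbon count, and a cyclopropyl or an unbranched butyl chain on the same carbonyl carbon would bear on that question. Compound 3 differs from compound 4 in more than one place, which leaves open how the ethyl and cyclobutyl exchange would read on the core of compound 3.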